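The compounds below may be only part of what the source reports. "The series", "measured", "known", "first", "only" and "open" are said of these compounds alone.

In an ADME assay on HFF cells (Homo sapiens) for cytotoxicity, read by resazurin assay, with a stated time of 96 h (on this read-out higher numbers stand for lower toxicity in this test and lower numbers for higher toxicity in this test), compound 3 (`CN1CCN(c2ccc3nc(-c4cccc(-c5cccs5)c4)c(-c4ccncc4)n3n2)CC1`) gives 6700 nM. Two compounds with the same core offer a comparison: compound 1 (`CN1CCN(c2ccc3nc(-c4cccc(-c5ccccc5)c4)c(-c4ccncc4)n3n2)CC1`) gives 10900 nM, and compound 2 (`CN1CCN(c2ccc3nc(-c4cccc5ccccc45)c(-c4ccncc4)n3n2)CC1`) gives 21300 nM. Compound 3 therefore sits level with compound 1 within the usual scatter, while compound 2 stands clearly apart from it with the higher number, meaning lower toxicity in this test.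

The next compound to consider is compound 4 (`CN1CCN(c2ccc3nc(-c4cccc(-c5ccsc5)c4)c(-c4ccncc4)n3n2)CC1`). It has the same atoms as compound 3, joined differently: thiophen-3-yl in place of thiophen-2-yl on an aromatic carbon.

Going by the values given here, no measured step makes this exact swap, so the evidence is indirect. The nearest guide is a 1.6-fold lower number from compound 1 to compound 3 (0.21 log units; within the scatter), where thiophen-2-yl took the place of phenyl and the change stayed within the scatter. The other step, a 3.2-fold lower number from compound 2 to compound 3 (0.50 log units; beyond the scatter), went beyond the scatter, but it exchanged naphthalen-1-yl for the whole 3-(thiophen-2-yl)phenyl group, so it says less about this swap. No step beyond the scatter is therefore expected in this assay, in either direction.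

The expected change is a 1.0-fold higher number from compound 3 to compound 4 (0.02 log units; within the scatter). For compound 4 the estimate is 7000 nM, with an expected range from 3700 nM to 13500 nM.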

Compound 4, half-maximal cytotoxic concentration in the HFF assay: 6300 nM
Beside the measured number, compound 4's estimate is 1.1-fold (0.05 log units) above it; the measured number falls inside the stated range.
By their numbers in the HFF assay, from the lowest: compounds 4, 3, 1 and 2 (each within the scatter of the next, the first and the last beyond it).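

Going by these compounds alone, in the HFF assay the swap of thiophen-2-yl for thiophen-3-yl gives a 1.1-fold lower number from compound 3 to compound 4 (0.03 log units; within the scatter) and so shows something the earlier compounds could not: on this six-membered aromatic ring of carbon only, meta to a large group, the point at which the sulfur-containing ring is attached makes no difference this test can resolve. Compound 4 also repeats the picture set by compound 3 in the HFF assay, since a 1.7-fold lower number from compound 1 to compound 4 (0.24 log units; within the scatter) still leaves the phenyl compound within reach, while a 3.4-fold lower number from compound 2 to compound 4 (0.53 log units; beyond the scatter) keeps the naphthalen-1-yl compound apart whichever thiophene isomer is used. The same swap in a physicochemical assay for lipophilicity (on this read-out higher numbers stand for higher lipophilicity and lower numbers for lower lipophilicity), gives no change at the digits printed from compound 3 to compound 4 (within the scatter) with compound 3 at 5 and compound 4 at 5 and the data shown offer no explanation for either result.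

From the compounds shown here alone, it remains open whether this flat response would hold for a group of a different kind at this position, such as a primary amine or a carboxylic acid in place of thiophen-3-yl. The compounds shown also leave open whether a longer chain between the two rings would keep the number in the same range or move it beyond the usual scatter.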